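This account rests on a few compounds, and the source may have more. Where it says the series, first, only, none or still open, it means among the compounds named here.

Compound 2 `COc1ccc2c(=O)c(/C=C/C(=O)Nc3ccc(C)cc3)coc2c1` gives 17500 nM in a functional assay on A549 cells (Homo sapiens) for inhibition, read by MTT assay, with a stated time of 48 h (on this read-out lower numbers stand for stronger inhibition and higher numbers for weaker inhibition), the highest of the two plain numbers reported. Compound 1 `COc1ccc2c(=O)c(/C=C/C(=O)Nc3cccc(Cl)c3)coc2c1` gives 470 nM, and the step of a 37-fold higher number from compound 1 to compound 2 (1.57 log units; beyond the scatter) shows how much this amide substituent matters. Compound 3 `O=C(/C=C/c1coc2cc(O)ccc2c1=O)NCc1ccccc1` gives > 100000 nM, which is a limit of the assay rather than a number.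

Compound 4 `COc1ccc(CNC(=O)/C=C/c2coc3cc(OC)ccc3c2=O)cc1` differs from compound 2 by 4-methoxybenzyl in place of 4-methylphenyl on an amide-type nitrogen. Within the data shown here, no measured step covers this change directly: the single step, a 37-fold higher number from compound 1 to compound 2 (1.57 log units; beyond the scatter), alters a different group, and compound 3 differs from compound 2 in two places at once. Since compound 2 is already weak, a step of a 2.3-fold higher number from compound 2 to compound 4 (0.36 log units; beyond the scatter) is expected in this assay, towards a higher number. The estimate for compound 4 is 40000 nM, with a range from 10000 nM to 150000 nM.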

Compound 4, half-maximal inhibitory concentration: 22500 nM
Compound 4: the middle estimate sits 1.8-fold (0.25 log units) above what was measured, and the stated range covers the measured number.
By their numbers in this assay, from the lowest: compound 1; then compounds 2 and 4 (each within the scatter of the next). At a limit, above all of these: compound 3.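

In this assay, 4-methoxybenzyl and 4-methylphenyl on the amide-type nitrogen cannot be told apart, with a 1.3-fold higher number from compound 2 to compound 4 (0.11 log units; within the scatter) as the step. The swap from 3-chlorophenyl gives a very different result, with a 48-fold higher number from compound 1 to compound 4 (1.68 log units; beyond the scatter) as the step, so compound 1 stands apart from both compound 2 and compound 4. Nothing measured here explains this difference.

As far as these compounds go, it stays open whether the chlorine or the ring sitting directly on the nitrogen matters more for compound 1, and a 3-chlorobenzyl group would help separate the two. From the compounds shown here alone, how an amine on that ring would behave also remains open.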